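The compounds below may be only part of what the source reports. "The series", "measured", "known", "first", "only" and "open" are said of these compounds alone.

Compound 1 `Nc1nc(N2CCN(C(=O)C3CCCCC3)CC2)c2cc(F)sc2n1` gives > 10000 nM in a functional assay on cells (Lymphocyte) (on this read-out higher numbers stand for weaker inhibition and lower numbers for stronger inhibition), which is a limit of the assay and not a number.
Compound 2 `Nc1nc(N2CCN(C(=O)COc3ccc(Cl)cc3)CC2)c2ccsc2n1` gives 330 nM in this assay.

Compound 1 stands at the limit of > 10000 nM in this assay, at which 1 of the 2 values shown sits, so its place on the scale is known only as a limit. Compound 2, by contrast, has a measured value. For the measured compounds named here, no two measured compounds differ in a single place, so no measured step is available here. The next compound, compound 3 `CC(C)N(C(=O)N1CCN(c2nc(N)nc3sc(F)cc23)CC1)C(C)C`, differs from compound 1 by diisopropylamino in place of cyclohexyl on a carbonyl carbon. Because compound 1 sits at the limit of > 10000 nM in this assay, at which 1 of the 2 values shown sits, the size and direction of this step cannot be read from the measured compounds; the expected step of a number no higher from compound 1 to compound 3 (the limit leaves the size open) is therefore set at none beyond the scatter. Compound 3 is accordingly estimated to give about 10000 nM in this assay, with an expected range from 2500 nM to 40000 nM.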

Compound 3, half-maximal inhibitory concentration: 8200 nM
The estimate for compound 3 lay 1.2-fold (0.09 log units) above the measured number; the range from low to high includes it.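

In this assay compound 1 gives > 10000 nM, which is a limit and not a number. Diisopropylamino in place of cyclohexyl on a carbonyl carbon gives an at least 1.2-fold lower number from compound 1 to compound 3 (0.08 log units; that floor lies within the scatter), so a group with no ring at this place yields a measured value, and the change is known only as a floor that does not go beyond the scatter. The true size of the step remains unread, as compound 1 marks the edge of the measurable range: the limit of > 10000 nM in this assay, at which 1 of the 3 values shown sits.

As far as these compounds go, whether a morpholine, a dimethylamino group or a longer alkyl chain on this carbonyl carbon would move the number further remains open. Compound 2 differs from compound 1 and compound 3 in more than one place, so the compounds shown do not connect it to this step.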